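The source may report more compounds than this note shows. Statements on the series, on what has been measured and on what is new or still open speak of the compounds shown alone.

Three compounds were examined in an ADME assay on IMR-90 cells (Homo sapiens) for cytotoxicity, read by CellTiter-Blue, with a stated time of 46 h; on this read-out lower numbers stand for an effect already at smaller amounts and higher numbers for an effect only at larger amounts of compound. Compound 1 `CC(C)(C)C1CCN(S(=O)(=O)c2ccc(NC(=O)c3ccc([N+](=O)[O-])o3)cc2)CC1` carries a 5-nitrofuran-2-yl on a carbonyl carbon whose other neighbours are an amide-type nitrogen, and compound 2 `CC(C)(C)C1CCN(S(=O)(=O)c2ccc(NC(=O)c3ccc([N+](=O)[O-])s3)cc2)CC1` carries a 5-nitrothiophen-2-yl in that place. Compound 1 reaches only a limit of the assay, > 25000 nM in this assay. Compound 2 likewise reaches only a limit, > 25000 nM in this assay. The change from compound 2 to compound 1 is 5-nitrofuran-2-yl in place of 5-nitrothiophen-2-yl on a carbonyl carbon and its step, a step that the two limits leave unreadable from compound 2 to compound 1, cannot be read because the limit of > 25000 nM in this assay, at which 3 of the 3 values shown sit, is where both values sit. Compound 3 `CC1(C)CCN(S(=O)(=O)c2cccc(NC(=O)c3ccc([N+](=O)[O-])s3)c2)CC1` differs from compound 2 in its core; the difference between the two cores is not broken down here. Compound 3 also shows only a limit, > 25000 nM in this assay. Compound 4 `CC1(C)CCN(S(=O)(=O)c2cccc(NC(=O)c3ccc([N+](=O)[O-])o3)c2)CC1` arises from compound 3 by the same change, (5-nitrofuran-2-yl in place of 5-nitrothiophen-2-yl on a carbonyl carbon). Given that compound 3 sits at the limit of > 25000 nM in this assay, at which 3 of the 3 values shown sit, the step from compound 3 to compound 4 is expected to be a step that the limit leaves unreadable from compound 3 to compound 4, unreadable like the earlier one. Compound 4 is therefore expected to give about 40000 nM in this assay, between 15000 nM and 120000 nM, most likely again reported only as a limit.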

Compound 4, half-maximal effective concentration: > 25000 nM
Compound 4 gave a limit, no number; the forecaster's own chance of this, stated with the estimate: 85%; the middle value lies beyond the limit too.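

Compound 3 and compound 4 both give only a limit, so the step between them cannot be read, and no new step emerges: the limit of > 25000 nM in this assay, at which 4 of the 4 values shown sit.

The compounds shown leave open whether 5-nitrofuran-2-yl in place of 5-nitrothiophen-2-yl on a carbonyl carbon changes the result in this assay at all, and what number any of these compounds would give there.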